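A few compounds are considered here, and "the series" means these few. Any claim that something is new, unique, unknown or untested is made for them only; others in the source may bear on it.

Measured so far:
compound 1, `O=S(=O)(c1cccc(F)c1)c1cnc2cc(F)ccc2c1-c1ccc(Cl)cc1`: 0.98 mL/min
compound 2, `Cc1ccc(S(=O)(=O)c2cnc3cc(F)ccc3c2-c2cccc(F)c2)cc1F`: 0.41 mL/min

In an ADME assay on microsomes from liver (Homo sapiens) for metabolic stability, tested at 2.5 uM (a lower number here means slower removal, a higher number faster removal of the compound), compound 1 gives 0.98 mL/min, while compound 2 gives 0.41 mL/min. For the measured compounds named here, compound 2 holds the lowest of the two numbers; its only neighbour, compound 1, sits at a higher number, and that gap lies beyond the usual scatter. Going by the values given here, the two differ in more than one place, so their values show only that the pair spans a real gap and nothing about any single change.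

Compound 3, `O=S(=O)(c1cccc(F)c1)c1cnc2cc(F)ccc2c1-c1cccc(F)c1`, differs from compound 2 by hydrogen in place of methyl on an aromatic carbon. The change sits on the aryl ring of the sulfonyl group, at a carbon ortho to a fluoro group and para to a large group; the shared core and the 3-fluorophenyl on it are unchanged.

Among the compounds with values here, no measured pair isolates this change. The step in this assay from compound 2 to compound 3 is expected to be small, a 1.2-fold higher number from compound 2 to compound 3 (0.09 log units; within the scatter), and not clearly beyond the scatter. Compound 3 is estimated at 0.5 mL/min, with a range from 0.22 mL/min to 1.1 mL/min.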

Compound 3, intrinsic clearance in a liver preparation (reported as CLH), per the amount of preparation that the assay uses: 0.24 mL/min
Compound 3: middle estimate off by 2.1-fold (0.32 log units), on the high side; the range from low to high includes it.
By their numbers in this assay, from the lowest: compounds 3 and 2 (each within the scatter of the next); then compound 1.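

In this assay, hydrogen in place of methyl on the aromatic carbon ortho to a fluoro group and para to a large group gives a 1.7-fold lower number from compound 2 to compound 3 (0.23 log units; within the scatter) and stays within the scatter, so this pair does not separate the two groups at this position. For the compounds shown here, the first single-place comparison beyond the scatter is 3-fluorophenyl in place of 4-chlorophenyl, with a 4.1-fold lower number from compound 1 to compound 3 (0.61 log units; beyond the scatter) for that exchange on the shared core. Nothing available explains either step.

As far as these compounds go, only methyl and hydrogen are compared at the carbon on the sulfonyl aryl ring, so an amine, a methoxy group or a longer chain there remains open. From the compounds shown here alone, it is also open whether the 3-fluorophenyl and 4-chlorophenyl comparison would hold with a 3-fluoro-4-methylphenyl on the sulfonyl group.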